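This account rests on a few compounds, and the source may have more. Where it says the series, first, only, none or still open, it means among the compounds named here.

Values in a functional assay (muscle tissue) with Cavia porcellus as the target (on this read-out higher numbers stand for an effect only at larger amounts of compound and lower numbers for an effect already at smaller amounts), so far:
- Compound 1 `COC(=O)C1=C(C)N=C(C)/C(=C(\O)OC)C1c1ccc(Cl)cc1` gives 8130 nM as its value
- Compound 2 `COC(=O)C1=C(C)N=C(C)/C(=C(\O)OC)C1c1cccc(N)c1` gives 2000 nM as its value
- Compound 3 `COC(=O)C1=C(C)N=C(C)/C(=C(\O)OC)C1c1ccc(I)cc1` is not yet measured

For the measured compounds named here, compound 2 stands lowest of the two numbers so far, with 2000 nM as its reading. The change to examine is 4-iodophenyl in place of 3-aminophenyl on a saturated ring carbon on a saturated ring carbon, next to the ring atom that bears a methoxycarbonyl group. In other words, 4-iodophenyl replaces 3-aminophenyl.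

Going by the values given here, one measured step bears on this: a 4.1-fold lower number from compound 1 to compound 2 (0.61 log units; beyond the scatter), modest in size and beyond the scatter. That step also involved 3-aminophenyl and a 4-halophenyl group, so the present change runs roughly opposite to it. Among the compounds with values here, no measured step compares 4-iodophenyl with 4-chlorophenyl, so this comparison is only an approximate guide.

The expectation in this assay is therefore a modest move to a higher number, of similar size to the measured step. The expected move is a 3.3-fold higher number from compound 2 to compound 3 (0.51 log units; beyond the scatter) in this estimate. Compound 3 is estimated at 6500 nM, with an expected range from 2200 nM to 19000 nM for its measurement.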

Compound 3, half-maximal effective concentration: 22900 nM
The estimate for compound 3 lay 3.5-fold (0.55 log units) below the measured number, and the stated range ends below it.
By their numbers in this assay, from the lowest: compound 2; then compound 1; then compound 3.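

Swapping the aryl group on the saturated ring carbon moves the reading in this assay by much more than the earlier compounds showed, with an 11-fold higher number from compound 2 to compound 3 (1.06 log units; beyond the scatter) as a large step in which 3-aminophenyl gives way to 4-iodophenyl. The halogen on the 4-halophenyl group also matters here, since a 2.8-fold higher number from compound 1 to compound 3 (0.45 log units; beyond the scatter) is a modest step beyond the scatter, so 4-chlorophenyl and 4-iodophenyl cannot be treated as equivalent at this position. Among the three compounds, the 3-aminophenyl group gives the lowest number and both halogen compounds read higher, but nothing available explains this order.

The step from 3-aminophenyl to 4-iodophenyl changes both the substituent and its place on the aromatic ring, so 4-aminophenyl and 3-iodophenyl analogues would be needed to tell these two changes apart. Also open, as far as these compounds go, is whether the rise from chloro to iodo continues as a trend through bromo, and whether a hydroxyl or a methoxy group at the place of the amino group would keep the lower number of compound 2.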